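Aryl urea swaps on a fluorophenoxy-cyclohexyl scaffold

The compounds below may be only part of what the source reports. "The series", "measured", "known", "first", "only" and "open" are said of these compounds alone.

Measured compounds:
compound 1, `O=C(Nc1ccccc1[N+](=O)[O-])N[C@H]1CC[C@H](Oc2ccc(F)cc2)CC1`: 3500 nM
compound 2, `O=C(Nc1ccccc1I)N[C@H]1CC[C@H](Oc2ccc(F)cc2)CC1`: > 20000 nM

In a functional assay on CRL2813 cells (Homo sapiens) for cytotoxicity, read by sulforhodamine B assay, with a stated time of 5 days (a lower number here means a stronger inhibitor, a higher number a weaker inhibitor), compound 1 gives 3500 nM. Compound 2 reaches only a limit of this assay, > 20000 nM, so on the numbers shown compound 2 stands at the weak end as a range, not a value, as shown by the limit of > 20000 nM in this assay, at which 1 of the 2 values shown sits. Among the compounds with values here, the single measured step, an at least 5.7-fold higher number from compound 1 to compound 2 (0.75 log units; beyond the scatter), is itself open-ended for the same reason.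

Compound 3, `COc1ccc(NC(=O)N[C@H]2CC[C@H](Oc3ccc(F)cc3)CC2)cc1`, differs from compound 2 by 4-methoxyphenyl in place of 2-iodophenyl on an amide-type nitrogen. That measured step bears on this change only loosely: it too swaps the aryl group on the urea nitrogen, and it shows that such a swap can move the number by at least a modest amount, but both the nitro and the iodo arm differ from the methoxy one now entering. With compound 2 at a limit, the size of the step to compound 3 cannot be fixed from the data, and the expected step of an at least 2.0-fold lower number from compound 2 to compound 3 (0.30 log units; that floor lies within the scatter) is therefore uncertain in both size and direction. Compound 3 is estimated at 10000 nM, within a range from 2500 nM to 30000 nM.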

Compound 3, half-maximal inhibitory concentration: > 20000 nM
Compound 3: a limit, no number (the forecaster's own chance of this, stated with the estimate: 40%); middle value at least 2.0-fold (0.30 log units) from the limit.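

Compound 3 gives > 20000 nM in this assay, which is a limit of the assay and not a number. Within the data shown here, exchanging the nitro-bearing aryl group on the urea for the methoxy-bearing one gives an at least 5.7-fold higher number from compound 1 to compound 3 (0.75 log units; beyond the scatter), so a second, quite different aryl group on the urea also leaves the cell read-out weaker than that of compound 1, which remains the only one of the three compounds with a readable value. The step between compound 2 and compound 3 cannot be read, so nothing can be said about the order of the 2-iodophenyl and 4-methoxyphenyl groups, because both compounds end at the same limit: the limit of > 20000 nM in this assay, at which 2 of the 3 values shown sit.

The compounds shown leave open whether the readable value of compound 1 goes with the nitro group itself or with where that group sits, since compound 3 differs from it in both the substituent and its placement. They also leave open how the same core would read with a nitrile, a carboxylic acid or an amine on the aryl group of the urea.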